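From Cyclohexyl to Tert-Butoxy on the Ester Carbonyl

A few compounds are considered here, and "the series" means these few. Any claim that something is new, unique, unknown or untested is made for them only; others in the source may bear on it.

Within the data shown here, compound 1 `C[C@@H](O)[C@H]1C(=O)N2C(C(=O)OCOC(=O)C3CCCCC3)=C(S[C@@H]3CN[C@H](C(=O)Nc4cccc(C(=O)O)c4)C3)[C@H](C)[C@H]12` is one of two compounds measured so far in an ADME assay for metabolic stability, read by LC-MS, with a stated time of 3 h, at pH 6.5, tested at 50 uM; a higher number here means that more of the compound is left, a lower number that less of the compound is left. In this assay compound 1 gives > 95%, which is a limit of the assay rather than a number. Compound 2 `Cc1oc(=O)oc1COC(=O)C1=C(S[C@@H]2CN[C@H](C(=O)Nc3cccc(C(=O)OCc4oc(=O)oc4C)c3)C2)[C@H](C)[C@@H]2[C@@H]([C@@H](C)O)C(=O)N12` gives > 95% in this assay, again a limit. Among the measured compounds shown here, both of the values shown thus sit at the same limit (the limit of > 95% in this assay, at which 2 of the 2 values shown sit), so nothing in the numbers separates compound 1 from compound 2, and no step between two measured compounds that differ in a single place is available.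

Compound 3 `C[C@@H](O)[C@H]1C(=O)N2C(C(=O)OCOC(=O)OC(C)(C)C)=C(S[C@@H]3CN[C@H](C(=O)Nc4cccc(C(=O)O)c4)C3)[C@H](C)[C@H]12` has not yet been measured. It differs from compound 1 in one place: tert-butoxy in place of cyclohexyl on a carbonyl carbon. For the measured compounds named here, with both measured values at the limit, there is no measured step to build on. The step of a number no higher from compound 1 to compound 3 (the limit leaves the size open) is expected to lie within the scatter, in no particular direction. Compound 3 is accordingly estimated at 95%, with a range from 85% to 100%, and most likely the assay would again report only the limit.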

Compound 3, percent of the compound remaining: > 95%
Compound 3: only a limit was reported; the forecaster's own chance of this, stated with the estimate: 70%; the middle value lies on the limit itself.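

In this assay compound 3 gives > 95%, which is a limit of the assay and not a number. No step between compound 1 and compound 3 can be read, as the values shown all stand at one limit: the limit of > 95% in this assay, at which 3 of the 3 values shown sit.

The compounds shown leave open whether tert-butoxy in place of cyclohexyl on a carbonyl carbon makes any difference in this assay.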